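A few compounds are considered here, and "the series" means these few. Any claim that something is new, unique, unknown or untested is made for them only; others in the source may bear on it.

Measured in this series:
compound 1 `CN1Cc2cc(ccc2S(=O)(=O)C2CC2)NC(=O)CCc2cccc(c2)[C@@H](Nc2ccc3c(N)ncc(F)c3c2)C1=O`: 0.217 h
compound 2 `CN1Cc2cc(ccc2S(=O)(=O)C2CC2)NC(=O)N(CC2CC2)CCc2cccc(c2)C(Nc2ccc3c(N)ncc(F)c3c2)C1=O`: 0.0833 h
compound 3 `COc1ccc2cc1[C@@H](C)CN(C)C(=O)Nc1ccc(S(=O)(=O)C3CC3)c(c1)CN(C)C(=O)[C@@H]2Nc1ccc2c(N)ncc(F)c2c1`: 0.0667 h

In an ADME assay on liver (Homo sapiens) for metabolic stability, using microsomes (a lower number here means that the compound disappears faster, a higher number that the compound lasts longer), compound 1 stands highest of the three numbers; compound 2 and compound 3 both sit lower, and both gaps to compound 1 lie beyond the usual scatter. Among the measured compounds shown here, no pair of measured compounds differs in a single place, so no step is available to anchor a new change. Compound 4 `CN1Cc2cc(ccc2S(=O)(=O)C2CC2)NC(=O)CCc2cc(ccc2OCC(F)F)[C@@H](Nc2ccc3c(N)ncc(F)c3c2)C1=O` is built from compound 1 by 2,2-difluoroethoxy in place of hydrogen on an aromatic carbon. The measured set holds no comparison of this kind, so the direction is open; the working expectation for the step from compound 1 to compound 4 is a small one, a 1.2-fold lower number from compound 1 to compound 4 (0.08 log units; within the scatter), not clearly beyond the scatter. For compound 4 in this assay the estimate is 0.18 h, expected to fall between 0.07 h and 0.45 h.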

Compound 4, half-life: 0.533 h
Compound 4: middle estimate off by 3.0-fold (0.47 log units), on the low side, and the stated range ends below it.
By their numbers in this assay, from the lowest: compounds 3 and 2 (each within the scatter of the next); then compound 1; then compound 4.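

In this assay, 2,2-difluoroethoxy in place of hydrogen on an aromatic carbon brings a 2.5-fold higher number from compound 1 to compound 4 (0.39 log units; beyond the scatter) and gives the only single-place step shown for the series. This position, ortho to a fused ring and para to a fused ring, therefore accepts the added group with no loss of half-life. Nothing measured bears on the reason for the rise.

On these data alone, whether the rise requires the fluorine atoms remains open, and a plain ethoxy group on the same carbon would test this. As far as these compounds go, whether a chlorine atom there gives a similar step also remains open.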